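The source may hold more compounds than are shown below. What is called first, only, known or untested is meant among the compounds shown, and "the series" means these compounds.

Compound 1 `CN1CCN(c2ccc(Nc3ncc4nc(Nc5ccccc5)n([C@@H]5CCNC5)c4n3)cc2)CC1`: 65 nM in a functional assay on HCC827 cells (Homo sapiens) for antiproliferative activity, read by MTT assay, with a stated time of 72 h; a lower number here means a stronger inhibitor, a higher number a weaker inhibitor. Compound 2 `CN1CCN(c2ccc(Nc3ncc4nc(Nc5ccc(F)cc5)n([C@@H]5CCNC5)c4n3)cc2)CC1`: 300 nM. Compound 3 `CN1CCN(c2ccc(Nc3ncc4nc(Nc5ccc(F)cc5)n([C@H]5CCCC(NC(=O)OC(C)(C)C)C5)c4n3)cc2)CC1`: 120 nM.

Among these three, compound 2 gives the highest number; compound 3 comes nearest to it, and compound 1 stands furthest away. Within the data shown here, the only measured single-point step, a 4.6-fold higher number from compound 1 to compound 2 (0.66 log units; beyond the scatter), concerns the fluoro substituent and does not touch the position altered here. Compound 4 `CN1CCN(c2ccc(Nc3ncc4nc(Nc5ccc(F)cc5)n(-c5cccc(NC(=O)CO)c5)c4n3)cc2)CC1` differs from compound 2 as follows: 3-(((hydroxymethyl)carbonyl)amino)phenyl in place of pyrrolidin-3-yl on an aromatic nitrogen. Among the measured compounds shown here, no measured pair shows this exchange; compound 3, which carries a different group at that place, gives a lower number than compound 2, but it is not a matching comparison. A modest step toward a lower number is therefore expected, a 2.0-fold lower number from compound 2 to compound 4 (0.30 log units; within the scatter), with wide uncertainty. Compound 4 is estimated at 150 nM, between 40 nM and 600 nM.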

Compound 4, half-maximal inhibitory concentration: 7.5 nM
Beside the measured number, compound 4's estimate is 20-fold (1.30 log units) above it; measured number below the stated range.
By their numbers in this assay, from the lowest: compound 4; then compounds 1 and 3 (each within the scatter of the next); then compound 2.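

Replacing pyrrolidin-3-yl with 3-(((hydroxymethyl)carbonyl)amino)phenyl on the aromatic nitrogen gives a 40-fold lower number from compound 2 to compound 4 (1.60 log units; beyond the scatter) in this assay and is the only step shown at this position. It shows that this place accepts a six-membered aromatic ring of carbon only, bearing an amide chain, and that the exchange can produce a large change in the number. No evidence on the cause of this step is available.

The compounds shown leave open whether the phenyl ring or its amide chain accounts for the step. An unsubstituted phenyl, or an amine on that ring in place of the amide, would separate the two.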